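Trifluoromethyl to methoxy: is a flat series expected to stay flat?

The compounds below may be only part of what the source reports. "The series", "measured", "known", "first", "only" and "open" are said of these compounds alone.

Values measured in a functional assay for inhibition; a higher number here means a weaker inhibitor, a lower number a stronger inhibitor
compound 1 `O=C(Nc1ccc(S(=O)(=O)Nc2cc(F)c(O)c(F)c2)cc1)c1ccccc1` gives 68600 nM
compound 2 `O=S(=O)(Nc1cc(F)c(O)c(F)c1)c1ccc(C(F)(F)F)cc1` gives 66000 nM
compound 3 `O=S(=O)(c1ccccc1)N(Cc1ccc(Br)cc1F)c1cc(F)c(O)c(F)c1` gives 66000 nM

Compound 2 at 66000 nM stands level with compound 3 at 66000 nM. Compound 1 at 68600 nM lies within the usual scatter of both, so these three numbers cannot be ranked.

The next compound, compound 4 `COc1ccc(S(=O)(=O)Nc2cc(F)c(O)c(F)c2)cc1`, has not yet been measured. It differs from compound 2 in one place, with methoxy in place of trifluoromethyl on an aromatic carbon, para to a large group: methoxy in place of trifluoromethyl on an aromatic carbon.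

Within the data shown here, only one measured step touches this carbon. It is a 1.0-fold lower number from compound 1 to compound 2 (0.02 log units; within the scatter), with trifluoromethyl in place of benzamido, and it stays within the scatter. On that evidence, no step beyond the scatter is expected in this assay for the new swap. Among the measured compounds shown here, the evidence is thin, though: it is a single step, and no measured compound carries methoxy. The range around the estimate is therefore kept wide.

The expected change is a 1.1-fold lower number from compound 2 to compound 4 (0.04 log units; within the scatter), which is no more than the scatter. For compound 4 the estimated value is 60000 nM, with an expected range from 22000 nM to 130000 nM.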

Compound 4, half-maximal inhibitory concentration: 55100 nM
Beside the measured number, compound 4's estimate is 1.1-fold (0.04 log units) above it; measured number inside the range.
By their numbers in this assay, from the lowest: compounds 4, 2, 3 and 1 (each within the scatter of the next).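

With methoxy, the carbon now carries a group with an oxygen, a hydrogen-bond acceptor and only 2 heavy atoms, yet in this assay replacing trifluoromethyl with methoxy leaves the result within the scatter (a 1.2-fold lower number from compound 2 to compound 4 (0.08 log units; within the scatter)). The comparison with the much larger benzamido group in compound 1 also stays within the scatter (a 1.2-fold lower number from compound 1 to compound 4 (0.10 log units; within the scatter)), so benzamido, trifluoromethyl and methoxy on this carbon, which differ in size and in hydrogen-bond acceptors, give numbers that cannot be told apart in this set of compounds. Nothing available explains why these swaps produce no measurable shift, so the flat result stands as an observation without a cause.

The compounds shown leave open whether any group on this carbon can move the number beyond the scatter, since an amine, a carboxylic acid and a longer chain such as butoxy are all absent from them. They also leave open whether a bare hydrogen at this carbon would give a number within the scatter of compound 2 and compound 4, which would show how much the group there matters at all.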